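Aryl carbamates on a shared core: inhibition still absent

The source may report more compounds than this note shows. Statements on the series, on what has been measured and on what is new or still open speak of the compounds shown alone.

Measured so far:
Compound 1, `COc1cccc(NC(=O)Oc2cc(=O)n(CCCO)c3c2CC(CC=C(C)C)C(C)(C)C3)c1`; in a functional assay on PANC-1 cells (Homo sapiens) for inhibition, read by MTT assay, with a stated time of 24 h, tested at 10 uM (a lower number here means less inhibition, a higher number more inhibition at the concentration tested (going by the name of the read-out)), compound 1 gives 0%.
Compound 2, `CC(C)=CCC1Cc2c(OC(=O)Nc3ccc(F)cc3)cc(=O)n(CCCO)c2CC1(C)C`; in this assay compound 2 gives 0%.
Compound 3, `CC(C)=CCC1Cc2c(OC(=O)Nc3ccc(F)c(F)c3)cc(=O)n(CCCO)c2CC1(C)C`; in this assay compound 3 gives 0%.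

Compound 3 stands level with compound 1 and compound 2. Every step measured so far is flat: no change at the digits printed from compound 1 to compound 2 (within the scatter), no change at the digits printed from compound 1 to compound 3 (within the scatter), no change at the digits printed from compound 2 to compound 3 (within the scatter). Two of these exchange the whole aryl group on the amide-type nitrogen, one adds a single fluoro, and none moves the read-out.

Compound 4, `CC(C)=CCC1Cc2c(OC(=O)Nc3cccc(C(F)(F)F)c3)cc(=O)n(CCCO)c2CC1(C)C`, continues this line: 3-(trifluoromethyl)phenyl in place of 3,4-difluorophenyl on an amide-type nitrogen. The aryl swaps from compound 1 to compound 2 and from compound 1 to compound 3 bear most directly on it, and both gave nothing. With three aryl variants all at the same level, the expected step of a number 2 percentage points higher from compound 3 to compound 4 (within the scatter) is none beyond the scatter. Compound 4 is estimated at 2%, with a range from -8% to 12%.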

Compound 4, a percentage reported as inhibition, at one concentration (the size of the read-out at that concentration, not a potency): 0%
Estimate against measurement, compound 4: 2 percentage points above; the range from low to high includes it.
By their numbers in this assay, from the lowest: compounds 1, 2, 3 and 4 (each within the scatter of the next).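

Putting 3-(trifluoromethyl)phenyl on the amide-type nitrogen extends the flat picture to a fourth aryl group, and in this assay the result is no change at the digits printed from compound 3 to compound 4 (within the scatter), with no change at the digits printed from compound 2 to compound 4 (within the scatter) and no change at the digits printed from compound 1 to compound 4 (within the scatter). Among these compounds, this exchange is the first to bring in trifluoromethyl, a larger group by heavy-atom count than the 3,4-difluorophenyl it replaces, yet all four aryl variants remain level. No supporting data bear on this result.

As far as these compounds go, whether an aryl group carrying an amine or a carboxylic acid, or a longer alkyl chain in place of the aryl group, would shift the read-out at this nitrogen remains open.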